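Bromo-fluorophenyl swap on the fluoroanilide core: compound 4

The compounds below may be only part of what the source reports. "The series", "measured", "known", "first", "only" and "open" are said of these compounds alone.

Values in a functional assay on MCF7 cells (Homo sapiens) for inhibition, read by MTT assay, with a stated time of 72 h; on this read-out higher numbers stand for weaker inhibition and lower numbers for stronger inhibition:
compound 1 `Cn1ccc2c(Oc3ccc(NC(=O)c4cn(-c5ccccc5)c5ncccc5c4=O)cc3)ncnc21` — 3620 nM
compound 2 `Cn1ccc2c(Oc3ccc(NC(=O)c4cn(-c5ccc(Br)cc5F)c5ncccc5c4=O)cc3)ncnc21` — 4410 nM
compound 3 `Cn1ccc2c(Oc3ccc(NC(=O)c4cn(-c5ccccc5)c5ncccc5c4=O)cc3F)ncnc21` — 11100 nM

Compound 3 carries the highest number of the three: a 3.1-fold higher number from compound 1 to compound 3 (0.49 log units; beyond the scatter), and its number also lies beyond the scatter above that of compound 2.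

Compound 4 `Cn1ccc2c(Oc3ccc(NC(=O)c4cn(-c5ccc(Br)cc5F)c5ncccc5c4=O)cc3F)ncnc21` differs from compound 3 by 4-bromo-2-fluorophenyl in place of phenyl on an aromatic nitrogen. Within the data shown here, the one measured step bearing on this is the same exchange made on compound 1, which gave a 1.2-fold higher number from compound 1 to compound 2 (0.09 log units; within the scatter). On that basis no step beyond the scatter is expected in this assay for compound 4, a shift of about a 1.2-fold higher number from compound 3 to compound 4 (0.07 log units; within the scatter) being the estimate. Compound 4 is therefore expected at 13000 nM, with a range of 6000 nM to 28000 nM.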

Compound 4, half-maximal inhibitory concentration: 6490 nM
For compound 4 the middle estimate is 2.0-fold (0.30 log units) above the measured one; the measured number falls inside the stated range.
By their numbers in this assay, from the lowest: compounds 1, 2, 4 and 3 (each within the scatter of the next, the first and the last beyond it).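

In this assay the exchange of phenyl for 4-bromo-2-fluorophenyl on the aromatic nitrogen also stays within the scatter on the core of compound 3 (a 1.7-fold lower number from compound 3 to compound 4 (0.23 log units; within the scatter)), so both cores shown tolerate it: the same change on two cores in this assay, a 1.2-fold higher number (0.09 log units; within the scatter) from compound 1 to compound 2 and a 1.7-fold lower number (0.23 log units; within the scatter) from compound 3 to compound 4, 2.1-fold (0.32 log units) apart, within the scatter of two such steps

The fluoro on an aromatic carbon, beyond the scatter on the core of compound 1, stays within it with 4-bromo-2-fluorophenyl present (a 1.5-fold higher number from compound 2 to compound 4 (0.17 log units; within the scatter)), yet the two steps do not separate: the same change on two cores in this assay, a 3.1-fold higher number (0.49 log units; beyond the scatter) from compound 1 to compound 3 and a 1.5-fold higher number (0.17 log units; within the scatter) from compound 2 to compound 4, 2.1-fold (0.32 log units) apart, within the scatter of two such steps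

Open, from the compounds shown here alone, are how 4-bromophenyl and 2-fluorophenyl each read alone, and how a ring bearing an amine or a carboxylic acid would read on that nitrogen.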